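Carboxy for methylsulfanyl on the aryl tail of compound 2

The source may report more compounds than this note shows. Statements on the series, on what has been measured and on what is new or still open speak of the compounds shown alone.

Compound 1 `O=C(CCCCCc1cccc(I)c1)N1CCOC1=O` gives 3120 nM in an assay on HEK293 cells for inhibition of N-acylethanolamine-hydrolyzing acid amidase (Rattus norvegicus), read by LC-MS, with a stated time of 30 min; on this read-out lower numbers stand for stronger inhibition and higher numbers for weaker inhibition. Compound 2 `CSc1ccc(CCCCCC(=O)N2CCOC2=O)cc1` reaches only > 20000 nM in this assay, a limit of the assay rather than a number. Compound 2 therefore stands at the limit of > 20000 nM in this assay, at which 1 of the 2 values shown sits, the weaker end of what has been seen. Compound 3 `O=C(O)c1ccc(CCCCCC(=O)N2CCOC2=O)cc1` carries the change (carboxy in place of methylsulfanyl on an aromatic carbon), carboxy in place of methylsulfanyl on an aromatic carbon. Among the compounds with values here, no measured step covers this change. Compound 3 is expected to remain near that limit, so the step that the limit leaves unreadable from compound 2 to compound 3 is estimated as none beyond the scatter. Compound 3 is estimated at 25000 nM, within a range from 6000 nM to 100000 nM.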

Compound 3, half-maximal inhibitory concentration: > 20000 nM
Compound 3 was reported as a limit; the forecaster's own chance of this, stated with the estimate: 65%; the middle value is on the limit's open side.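

Compound 2 and compound 3 both stand at a limit in this assay, so no step can be read for carboxy in place of methylsulfanyl: the limit of > 20000 nM in this assay, at which 2 of the 3 values shown sit.

The compounds shown leave open whether this change alters inhibition at all.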